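Hydroxyphenyl Replaces Chlorophenyl in a Weakly Cytotoxic Series

The source may report more compounds than this note shows. Statements on the series, on what has been measured and on what is new or still open speak of the compounds shown alone.

Compound 1, `Fc1cccc(-c2nc(Nc3ccccc3)c3ccccc3n2)c1`: in a functional assay on U-937 cells (Homo sapiens) for cytotoxicity, read by MTT assay, with a stated time of 48 h (a lower number here means a stronger inhibitor, a higher number a weaker inhibitor), compound 1 reaches only the limit > 50000 nM.
Compound 2, `Fc1cccc(-c2nc(Nc3ccc(Cl)cc3)c3cc(F)ccc3n2)c1`: in this assay compound 2 gives 32700 nM.
Compound 3, `Fc1cccc(-c2nc(Nc3ccccc3Cl)c3cc(F)ccc3n2)c1`: in this assay compound 3 reaches only the limit > 50000 nM.

Within the data shown here, compound 2 therefore holds the only true number in this set; the other two values are limits, as the limit of > 50000 nM in this assay, at which 2 of the 3 values shown sit, shows. Compound 4, `Oc1cccc(Nc2nc(-c3cccc(F)c3)nc3ccc(F)cc23)c1`, differs from compound 2 by 3-hydroxyphenyl in place of 4-chlorophenyl on a nitrogen on an aromatic ring. Among the measured compounds shown here, the only measured step, an at least 1.5-fold higher number from compound 2 to compound 3 (0.18 log units; that floor lies within the scatter), shifts the chlorine around the same ring and stays within the scatter. For the measured compounds named here, no measured step exchanges chlorine for a hydroxyl group, so the expectation rests on the weak activity of the whole set. Compound 4 is expected near 40000 nM, between 15000 nM and 100000 nM. That estimate means a step of a 1.2-fold higher number from compound 2 to compound 4 (0.09 log units; within the scatter), not beyond the scatter.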

Compound 4, half-maximal inhibitory concentration: > 50000 nM
Compound 4: a limit, no number (the forecaster's own chance of this, stated with the estimate: 40%); at least 1.2-fold (0.09 log units) between middle value and limit.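

Putting 3-hydroxyphenyl in place of 4-chlorophenyl on the nitrogen gives an at least 1.5-fold higher number from compound 2 to compound 4 (0.18 log units; that floor lies within the scatter), so this change, which adds a hydrogen-bond donor and acceptor, brings no sign of stronger inhibition in this assay. As far as these compounds go, compound 4 gives a limit and not a number, so the true size of that step stays unknown, and the step between the two limits of compound 3 and compound 4 cannot be read. Compound 2 remains the only compound with a true number, and the set now stands at: the limit of > 50000 nM in this assay, at which 3 of the 4 values shown sit.

The compounds shown leave open whether an amine or a carboxylic acid in place of the hydroxyl group would give a true number in this assay.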